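This account rests on a few compounds, and the source may have more. Where it says the series, first, only, none or still open, it means among the compounds named here.

In an ADME assay on HepG2 cells (Homo sapiens) for cytotoxicity, read by MTT assay, with a stated time of 72 h (on this read-out lower numbers stand for stronger inhibition and higher numbers for weaker inhibition), compound 1 (`Cc1ccc(S(=O)(=O)Cc2nc(Nc3ccccc3)c3ccccc3n2)cc1`) has no number to start from, as its entry reads "nd(insoluble)" (no result reported). Within the data shown here, the only other readings are limits. Compound 2 (`Cc1ccc(S(=O)(=O)Cc2nc(Nc3cccc(C(F)(F)F)c3)c3ccccc3n2)cc1`) gives > 25000 nM, which is a limit and not a number. Compound 3 (`Cc1ccc(S(=O)(=O)Cc2nc(Nc3ccc(F)cc3)c3ccccc3n2)cc1`) gives > 15000 nM, which is also a limit. Among the measured compounds shown here, the single measured step, a step that the two limits leave unreadable from compound 2 to compound 3, therefore has no readable size, and it swaps 3-(trifluoromethyl)phenyl for 4-fluorophenyl rather than adding chloro.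

Compound 4 (`Cc1ccc(S(=O)(=O)Cc2nc(Nc3ccccc3Cl)c3ccccc3n2)cc1`) differs from compound 1 by chloro in place of hydrogen on an aromatic carbon, ortho to a large group, which turns phenyl into 2-chlorophenyl. With no number for compound 1 and no readable step, no size or direction of change can be expected from this assay itself. The expectation instead follows the level of the measured neighbours, so weak inhibition is anticipated. The estimated value for compound 4 is 25000 nM, with an expected range of 10000 nM to 60000 nM.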

Compound 4, half-maximal inhibitory concentration: > 50000 nM
Compound 4 ended at the assay's limit; the forecaster's own chance of this, stated with the estimate: 65%; at least 2.0-fold (0.30 log units) between middle value and limit.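

In this assay compound 4 gives > 50000 nM, which is a limit and not a number. Neither step to compound 4, from compound 2 or from compound 3, can be read. The compounds shown leave open whether any change on the anilino group shifts cytotoxicity at all.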